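Removing the Second Chloro from the Core of Compound 1

The source may report more compounds than this note shows. Statements on the series, on what has been measured and on what is new or still open speak of the compounds shown alone.

Among the compounds with values here, compound 1 `ClCc1ccc(Cn2cnc3nc(Cl)nc(Cl)c32)cc1` holds the lower of the two numbers known so far: in a functional assay on TK-10 cells (Homo sapiens) for cytotoxicity, read by sulforhodamine B assay, with a stated time of 48 h (on this read-out higher numbers stand for weaker inhibition of growth and lower numbers for stronger inhibition of growth), compound 1 gives 120 nM. Compound 2 `Nc1nc(Cl)c2ncn(Cc3cccc(CCl)c3)c2n1` differs from it in more than one place, and in this assay compound 2 gives 2390 nM, a gap beyond the usual scatter. Compound 3 `ClCc1ccc(Cn2cnc3ncnc(Cl)c32)cc1` arises from compound 1 by a single change, (hydrogen in place of chloro on an aromatic carbon). Within the data shown here, no measured pair isolates this change, so its size in this assay can only be estimated. A modest rise in number is expected, with the step of a 2.5-fold higher number from compound 1 to compound 3 (0.40 log units; beyond the scatter) lying close to the edge of the scatter. For compound 3 in this assay the estimate is 300 nM, within a range from 100 nM to 1000 nM.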

Compound 3, concentration for 50% growth inhibition: 1470 nM
Compound 3: middle estimate off by 4.9-fold (0.69 log units), on the low side, outside the stated range (above it).
By their numbers in this assay, from the lowest: compound 1; then compounds 3 and 2 (each within the scatter of the next).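

In this assay the chloro on the aromatic carbon between two ring nitrogen atoms proves to carry much of the activity of compound 1: hydrogen in its place gives a 12-fold higher number from compound 1 to compound 3 (1.09 log units; beyond the scatter), a large step. Within the data shown here, this is the first pair that differs in one place, so the weight of this chloro can be read directly with the rest of compound 1 unchanged. Nothing shown here accounts for the size of this step. On these data alone, whether a fluoro or a methoxy group at this position would keep the lower number remains open.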